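The source may report more compounds than this note shows. Statements on the series, on what has been measured and on what is new or still open speak of the compounds shown alone.

- compound 1 `COc1ccc(/C=C/c2cc(C)no2)cc1OC` gives 93200 nM as a measured number
- compound 2 `COc1ccc(/C=C/c2cc(C)no2)cc1` gives > 100000 nM as a limit

For the measured compounds named here, in an ADME assay on NIH3T3 cells (Mus musculus) for cytotoxicity, read by MTT assay, with a stated time of 72 h (on this read-out higher numbers stand for weaker inhibition and lower numbers for stronger inhibition), compound 1 gives 93200 nM as the only actual number so far. Compound 2 reports > 100000 nM as a limit and not a number.

Compound 3 `COc1cc(/C=C/c2cc(C)no2)ccc1O` is still unmeasured. Its difference from compound 1 is hydrogen in place of methyl on an oxygen on an aromatic ring in short, hydrogen in place of methyl on an oxygen on an aromatic ring, so methoxy becomes hydroxy.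

Going by the values given here, one measured step bears on this, and only loosely. It is an at least 1.0-fold higher number from compound 1 to compound 2 (0.03 log units; that floor lies within the scatter) and there hydrogen takes the place of methoxy on an aromatic carbon, so the whole group goes, whereas compound 3 keeps its oxygen. Among the compounds with values here, that step is a floor within the scatter, and no measured step covers the exact change. Compound 3 may also end as a limit, given the limit of > 100000 nM in this assay, at which 1 of the 2 values shown sits, in the data so far. The change expected is a 1.2-fold lower number from compound 1 to compound 3 (0.07 log units; within the scatter) and so none beyond the scatter in either direction. Compound 3 is estimated at 80000 nM with an expected range from 35000 nM to 100000 nM in this assay once it is measured.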

Compound 3, half-maximal inhibitory concentration: > 100000 nM
Compound 3 gave a limit, no number; the forecaster's own chance of this, stated with the estimate: 40%; middle value at least 1.2-fold (0.09 log units) from the limit.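

In this assay compound 3 gives > 100000 nM as a limit and not a number. Putting hydrogen in place of methyl on this oxygen, so that methoxy becomes hydroxy, gives an at least 1.0-fold higher number from compound 1 to compound 3 (0.03 log units; that floor lies within the scatter) as all that can be read, so the change shows no sign of stronger inhibition, while any weakening beyond that floor has no measured size. Compound 2 had already lost the other methoxy group whole, and compound 3 now shows that a change which keeps the oxygen also ends in a limit, so both single changes from compound 1 leave the scale of numbers, and such limits are now the commoner result here: the limit of > 100000 nM in this assay, at which 2 of the 3 values shown sit.

Neither step has a true size, so whether either change really weakens the effect beyond the scatter cannot be read from these values. From the compounds shown here alone, whether a longer chain on this oxygen, such as ethyl, or an amine in place of the hydroxy would give an actual number rather than a limit stays open.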